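This account rests on a few compounds, and the source may have more. Where it says the series, first, only, none or still open, it means among the compounds named here.

Measured compounds:
Compound 1, `N#Cc1c(-c2ccc(Cl)cc2)c(C#N)c(=O)n(/N=C/c2cn(-c3ccccc3)nc2-c2ccccc2)c1N`; in an ADME assay on NIH3T3 cells (Mus musculus) for cytotoxicity, read by MTT assay (on this read-out lower numbers stand for stronger inhibition and higher numbers for weaker inhibition), compound 1 gives 64 ug/mL.
Compound 2, `COc1cc(-c2c(C#N)c(N)n(/N=C/c3cn(-c4ccccc4)nc3-c3ccccc3)c(=O)c2C#N)cc(OC)c1OC`; in this assay compound 2 gives 64 ug/mL.

For the measured compounds named here, compound 2 stands level with compound 1 on the numbers so far: the step from compound 1 to compound 2 reads no change at the digits printed from compound 1 to compound 2 (within the scatter), so the exchange of the aryl group on that aromatic carbon left the read-out where it was. Compound 3, `N#Cc1c(-c2ccccc2[N+](=O)[O-])c(C#N)c(=O)n(/N=C/c2cn(-c3ccccc3)nc2-c2ccccc2)c1N`, carries the change (2-nitrophenyl in place of 3,4,5-trimethoxyphenyl on an aromatic carbon). Going by the values given here, only one measured step bears on this kind of exchange, and it is the step from compound 1 to compound 2, which stayed within the scatter. Among the compounds with values here, nothing among the measured compounds points to a move in either direction when the aryl group on this carbon is swapped again, and the data give no other step to weigh against it. The account therefore expects compound 3 to come out close to compound 2 in this assay, with a step of no change at the digits printed from compound 2 to compound 3 (within the scatter), that is, none beyond the scatter. For compound 3 the estimate in this assay is 64 ug/mL, within a range from 32 ug/mL to 128 ug/mL.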

Compound 3, half-maximal inhibitory concentration: > 200 ug/mL
Compound 3 was reported as a limit (the forecaster's own chance of this, stated with the estimate: 15%); at least 3.1-fold (0.49 log units) between middle value and limit.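

The earlier pair suggested that the aryl group on this carbon, opposite the ring nitrogen, could be exchanged without consequence in this assay, but 2-nitrophenyl shows that this does not hold for every aryl group. Set against 3,4,5-trimethoxyphenyl, the new group gives an at least 3.1-fold higher number from compound 2 to compound 3 (0.49 log units; beyond the scatter), and set against 4-chlorophenyl it gives an at least 3.1-fold higher number from compound 1 to compound 3 (0.49 log units; beyond the scatter), so on this read-out inhibition is weaker with 2-nitrophenyl than with either earlier group, and compound 3 goes against the flat picture left by compound 1 and compound 2. Both steps have only a lower bound, and the full size of the shift cannot be read, as compound 3 sits at a limit of the assay: the limit of > 200 ug/mL in this assay, at which 1 of the 3 values shown sits.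

The three compounds leave open whether the shift belongs to the nitro group itself or to its place on the phenyl ring, and they say nothing about why the read-out moved. A 4-nitrophenyl or a 2-aminophenyl group on the same carbon, with the rest of the core kept, would bear directly on that question.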